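Amine variation on the carbamate chain of compound 3

The source may report more compounds than this note shows. Statements on the series, on what has been measured and on what is new or still open speak of the compounds shown alone.

Three compounds of the shared core have numbers in an in vitro functional assay on CHO/Galpha16 cells for antagonist activity at C-C chemokine receptor type 8 (Homo sapiens), read by FLIPR; a higher number here means a weaker inhibitor, a lower number a stronger inhibitor. Compound 1 `CCOC(=O)N1CCC(NS(=O)(=O)c2ccc(NC(=O)c3ccncc3)c3ccccc23)CC1` gives 100 nM in this assay. Compound 2 `Cc1ccccc1C(=O)Nc1ccc(S(=O)(=O)NC2CCN(C(=O)OCCCN(C)C)CC2)c2ccccc12` gives 9.8 nM, and compound 3 `Cc1ccccc1C(=O)Nc1ccc(S(=O)(=O)NC2CCN(C(=O)OCCCN3CCCC3)CC2)c2ccccc12` gives 4.2 nM. Going by the values given here, the one single-point step so far is a 2.3-fold lower number from compound 2 to compound 3 (0.37 log units; beyond the scatter). Compound 3 therefore stands at the lowest of the three numbers; compound 2 is nearest, compound 1 furthest, both beyond the scatter.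

Compound 4 `Cc1ccccc1C(=O)Nc1ccc(S(=O)(=O)NC2CCN(C(=O)OCCCN3CC(C)OC(C)C3)CC2)c2ccccc12` continues the variation at the same position: 2,6-dimethylmorpholin-4-yl in place of pyrrolidin-1-yl on a saturated chain carbon, three bonds along the chain from an oxygen next to a carbonyl group. Among the compounds with values here, the only step that bears on this change is the modest one from compound 2 to compound 3, a 2.3-fold lower number from compound 2 to compound 3 (0.37 log units; beyond the scatter), which concerns a different pair of amines at this position; no measured step covers a six-membered ring with two hetero atoms here. On that basis the expectation is a change of a 1.4-fold higher number from compound 3 to compound 4 (0.15 log units; within the scatter) at most, not clearly beyond the scatter. Compound 4 is estimated at 6 nM, in the range 2 nM to 18 nM.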

Compound 4, half-maximal inhibitory concentration: 19.6 nM
Compound 4: middle estimate off by 3.3-fold (0.51 log units), on the low side; the whole stated range lies below it.
By their numbers in this assay, from the lowest: compound 3; then compounds 2 and 4 (each within the scatter of the next); then compound 1.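

In this assay, this position on the saturated chain is not indifferent to the amine: moving to 2,6-dimethylmorpholin-4-yl, a six-membered ring with 2 hetero atoms, gives a 4.7-fold higher number from compound 3 to compound 4 (0.67 log units; beyond the scatter), a step beyond the scatter. Against dimethylamino the same group gives a 2.0-fold higher number from compound 2 to compound 4 (0.30 log units; within the scatter), within the scatter, so the loss appears only against pyrrolidin-1-yl, and compound 2 and compound 4 cannot be ordered. No measurement shown assigns the step to the ring oxygen, the two methyl groups or the ring size.

As far as these compounds go, it stays open whether morpholin-4-yl without the two methyl groups, or piperidin-1-yl, would sit with compound 3 or with compound 4. Also open, from the compounds shown here alone, is how a 2-(pyrrolidin-1-yl)ethyl chain would compare with the 3-(pyrrolidin-1-yl)propyl chain of compound 3.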